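This account rests on a few compounds, and the source may have more. Where it says the series, first, only, none or still open, it means among the compounds named here.

Values in an ADME assay on MDCK cells (Canis lupus familiaris) for cytotoxicity, read by MTT assay, with a stated time of 24 h; on this read-out higher numbers stand for lower toxicity in this test and lower numbers for higher toxicity in this test:
- compound 1 `N#CCCN(Cc1cccs1)S(=O)(=O)c1ccc(Br)cc1`: > 173000 nM, a limit
- compound 2 `N#CCCN(Cc1ccco1)S(=O)(=O)c1ccc(Br)cc1`: > 180000 nM, a limit
- compound 3 `COc1ccc(S(=O)(=O)N(CCC#N)Cc2ccco2)cc1`: > 208000 nM, a limit

Compound 2 has only a limit, > 180000 nM, and no number. The values of the other two compounds are limits as well, so no order can be read among the three.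

The next compound, compound 4 `N#CCCN(Cc1ccc[nH]1)S(=O)(=O)c1ccc(Br)cc1`, has 1H-pyrrol-2-yl in place of furan-2-yl on a saturated chain carbon bound to a sulfonamide nitrogen.

The closest measured change is furan-2-yl in place of thiophen-2-yl at that same place, a step that the two limits leave unreadable from compound 1 to compound 2. Methoxy in place of bromo, on an aromatic carbon, is a change elsewhere in the molecule, a step that the two limits leave unreadable from compound 2 to compound 3. Neither gives a size to carry over, and neither gives a direction.

No step beyond the scatter is therefore expected in this assay, and the expected change is a number no higher from compound 2 to compound 4 (the limit leaves the size open). Compound 4 may well also be reported as a limit. For compound 4 the estimated value is 180000 nM, with an expected range from 80000 nM to 300000 nM.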

Compound 4, half-maximal cytotoxic concentration: > 181000 nM
Compound 4 was reported as a limit; the forecaster's own chance of this, stated with the estimate: 70%; at least 1.0-fold (0.00 log units) between middle value and limit.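

In this assay compound 4 gives only a limit, > 181000 nM. For the compounds shown here, compound 1 and compound 2 also stand as limits, so no step to compound 4 can be read. The compounds shown leave open whether exchanging thiophen-2-yl, furan-2-yl or 1H-pyrrol-2-yl changes this read-out at all.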